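Shorter hydroxamate chain replacing aryl hydroxamate on the urea

The compounds below may be only part of what the source reports. "The series", "measured", "known", "first", "only" and "open" are said of these compounds alone.

Measured compounds:
- Compound 1 `CCOc1cc(C(C)(C)C)ccc1C1=NC(c2ccc(Cl)cc2)C(c2ccc(Cl)cc2)N1C(=O)N1CCN(CCCCCC(=O)NO)CC1`: 7260 nM
- Compound 2 `CCOc1cc(C(C)(C)C)ccc1C1=NC(c2ccc(Cl)cc2)C(c2ccc(Cl)cc2)N1C(=O)NCCCCCCCC(=O)NO`: 7920 nM
- Compound 3 `CCOc1cc(C(C)(C)C)ccc1C1=NC(c2ccc(Cl)cc2)C(c2ccc(Cl)cc2)N1C(=O)N1CCN(Cc2ccc(C(=O)NO)cc2)CC1`: 3970 nM

The three compounds share one core and differ only in the hydroxamate-bearing arm. In a functional assay on MCF7 cells (Homo sapiens) for antiproliferative activity, read by CCK-8 assay, with a stated time of 72 h (a lower number here means a stronger inhibitor, a higher number a weaker inhibitor), compound 3 gives 3970 nM, the lowest of the three numbers, although its distance to compound 1, at 7260 nM, and to compound 2, at 7920 nM, lies within the scatter, so no order among them can be claimed.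

Compound 4 `CCOc1cc(C(C)(C)C)ccc1C1=NC(c2ccc(Cl)cc2)C(c2ccc(Cl)cc2)N1C(=O)N1CCN(CCCCC(=O)NO)CC1` is not yet measured. Relative to compound 3 the change is 3-(hydroxycarbamoyl)propyl in place of 4-(hydroxycarbamoyl)phenyl on a saturated chain carbon bound to an amine nitrogen in a ring. For the measured compounds named here, the one step that bears on it is a 1.8-fold lower number from compound 1 to compound 3 (0.26 log units; within the scatter), which went the other way and stayed within the scatter. Compound 4 carries a chain one carbon shorter than compound 1, so a small move back toward compound 1 is the expectation, with a 1.5-fold higher number from compound 3 to compound 4 (0.18 log units; within the scatter) estimated as a step that does not exceed the scatter. Compound 4 is therefore expected to give about 6000 nM in this assay, within a range of 3000 nM to 12000 nM.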

Compound 4, half-maximal inhibitory concentration: 9800 nM
Estimate against measurement, compound 4: 1.6-fold (0.21 log units) below; low and high end bracket the measured number.
By their numbers in this assay, from the lowest: compounds 3, 1, 2 and 4 (each within the scatter of the next, the first and the last beyond it).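

For the compounds shown here, at this position, on a saturated chain carbon bound to an amine nitrogen in a ring, 3-(hydroxycarbamoyl)propyl in place of 4-(hydroxycarbamoyl)phenyl gives a 2.5-fold higher number from compound 3 to compound 4 (0.39 log units; beyond the scatter) in this assay and so provides the first step to pass beyond the scatter. Among the saturated chains, hydroxycarbamoyl in place of (hydroxycarbamoyl)methyl gives only a 1.3-fold higher number from compound 1 to compound 4 (0.13 log units; within the scatter) and thus does not separate the two chain lengths. Nothing measured here gives a reason for either step.

The compounds shown leave open whether a longer chain at this position would stay within the scatter of compound 1. They also leave open how a carboxylic acid in place of the hydroxycarbamoyl group would read in this assay on the arm of compound 3.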